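Cyclohexyl acid substituent variation on the azaindole series

A few compounds are considered here, and "the series" means these few. Any claim that something is new, unique, unknown or untested is made for them only; others in the source may bear on it.

Measured compounds:
compound 1 `COc1ccc(F)cc1-c1c(F)cnc2[nH]c(C3=CCN([C@H]4CC[C@@H](CC(=O)O)CC4)CC3)cc12` — 48 nM
compound 2 `COc1ccc(F)cc1-c1c(F)cnc2[nH]c(C3=CCN([C@H]4CC[C@@H](C(=O)O)CC4)CC3)cc12` — 35 nM

In a functional assay on NCI-H929 cells (Homo sapiens) for antiproliferative activity, with a stated time of 24 h (a higher number here means a weaker inhibitor, a lower number a stronger inhibitor), compound 2 gives the lowest of two numbers, though the step of a 1.4-fold lower number from compound 1 to compound 2 (0.14 log units; within the scatter) is within the scatter, so compound 1 and compound 2 are not separated. Compound 3 `COc1ccc(F)cc1-c1c(F)cnc2[nH]c(C3=CCN([C@H]4CC[C@H](CC(=O)O)CC4)CC3)cc12` is not yet measured. Its change from compound 2 is 4-(carboxymethyl)cyclohexyl in place of 4-carboxycyclohexyl on an amine nitrogen in a ring. Among the compounds with values here, the only step that bears on it, a 1.4-fold lower number from compound 1 to compound 2 (0.14 log units; within the scatter), runs through the same pair of groups in the opposite direction and was within the scatter, so compound 3 is expected to sit near compound 2, with an expected step of a 1.3-fold higher number from compound 2 to compound 3 (0.11 log units; within the scatter) that stays within the scatter. Compound 3 is estimated at 45 nM with a range of 20 nM to 110 nM.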

Compound 3, half-maximal inhibitory concentration: 60 nM
Estimate against measurement, compound 3: 1.3-fold (0.12 log units) below, within the range that was stated.
By their numbers in this assay, from the lowest: compounds 2, 1 and 3 (each within the scatter of the next).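

In this assay, the two drawn configurations of the 4-(carboxymethyl)cyclohexyl group on the amine nitrogen in a ring are not separated, with a 1.3-fold higher number from compound 1 to compound 3 (0.10 log units; within the scatter). This pair tests configuration alone: the fact that compounds 1 and 3 differ only in the configuration as drawn. Exchanging 4-carboxycyclohexyl for 4-(carboxymethyl)cyclohexyl also stays within the scatter, with a 1.7-fold higher number from compound 2 to compound 3 (0.23 log units; within the scatter), so neither change separates the compounds at this position.

From the compounds shown here alone, it remains open whether 4-carboxycyclohexyl also shows no separation between configurations. Going by these compounds, it is also open whether a primary amide, an amine or a longer acid chain at this position would stay within the scatter.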